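Swapping a hydroxyethyl for a methylcarbamoyl on a pyrrolidine

This account rests on a few compounds, and the source may have more. Where it says the series, first, only, none or still open, it means among the compounds named here.

Of the compounds shown here, two sharing one core have been measured so far. Compound 1 `CCNC(=O)[C@@H]1CN[C@H](C(=O)N2CCC[C@H]2C#N)C1` carries an ethylcarbamoyl on a saturated ring carbon; in an assay on the whole organism (plasma, strain Sprague-Dawley) for inhibition of Dipeptidyl peptidase 4 (Rattus norvegicus), with a stated time of 6 h, at a dose of 1 mg/kg by the oral route (a higher number here means more inhibition at the dose given (going by the name of the read-out), a lower number less inhibition), compound 1 gives 60%. Compound 2 `N#C[C@@H]1CCCN1C(=O)[C@@H]1C[C@H](CCO)CN1` carries a 2-hydroxyethyl at that position instead, and in this assay compound 2 gives 64%. Going by the values given here, the only step recorded between them is a number 4 percentage points higher from compound 1 to compound 2 (within the scatter), so the two values are indistinguishable and compound 2 cannot be called the better of the pair.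

Compound 3 `CNC(=O)[C@@H]1CN[C@H](C(=O)N2CCC[C@H]2C#N)C1` is the next candidate. It differs from compound 2 as follows: methylcarbamoyl in place of 2-hydroxyethyl on a saturated ring carbon. Among the compounds with values here, the one step that bears on this change is the move from ethylcarbamoyl to 2-hydroxyethyl, which was within the scatter, so an essentially flat result is expected here as well, a number 4 percentage points lower from compound 2 to compound 3 (within the scatter). For compound 3 the expected value in this assay is 60%, with a likely range from 45% to 75%.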

Compound 3, a percentage reported as inhibition, in the whole organism at one dose (the size of the read-out at that dose, not a potency): 75%
Estimate against measurement, compound 3: 15 percentage points below; the range from low to high includes it.
By their numbers in this assay, from the lowest: compounds 1 and 2 (each within the scatter of the next); then compound 3.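

Unlike the first swap, this one moves the number: in this assay, methylcarbamoyl in place of 2-hydroxyethyl on this saturated ring carbon gives a number 11 percentage points higher from compound 2 to compound 3 (beyond the scatter) and so the position does respond to what it carries. Even a small edit counts, since removing one methyl from the end of the amide chain gives a number 15 percentage points higher from compound 1 to compound 3 (beyond the scatter) and turns ethylcarbamoyl into methylcarbamoyl. Nothing available explains either step.

As far as these compounds go, with only these three compounds, it remains open whether shortening further to an unsubstituted carbamoyl would raise the number again or lower it. From the compounds shown here alone, it is also open how a carboxylic acid or an aminomethyl group at this ring carbon would compare with methylcarbamoyl.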